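This account rests on a few compounds, and the source may have more. Where it says the series, first, only, none or still open, it means among the compounds named here.

Compound 2 `COc1ccc(/C=C/C(=O)Nc2cc3c(Nc4ccc(F)c(Cl)c4)ncnc3cc2OC)cc1` carries a methoxy group on the aromatic ring of the shared core, and in a functional assay on PC-3 cells (Homo sapiens) for cytotoxicity, read by MTT assay, with a stated time of 72 h (a lower number here means a stronger inhibitor, a higher number a weaker inhibitor), compound 2 gives "not active" (no number reported), so no single number stands for it. Its two neighbours show where the set sits: compound 1 `COc1cc2ncnc(Nc3ccc(F)c(Cl)c3)c2cc1NC(=O)/C=C/c1ccc(F)cc1Cl` gives 32700 nM and compound 3 `COc1ccc(/C=C/C(=O)Nc2cc3c(Nc4ccc(F)c(Cl)c4)ncnc3cc2OC)c(OC)c1` gives 38500 nM, and the step of a 1.2-fold higher number from compound 1 to compound 3 (0.07 log units; within the scatter) alters the aryl group on the double-bonded chain carbon, not the oxygen on the aromatic ring. Compound 4 `COc1ccc(/C=C/C(=O)Nc2cc3c(Nc4ccc(F)c(Cl)c4)ncnc3cc2O[C@H]2CCOC2)cc1` differs from compound 2 by oxolan-3-yl in place of methyl on an oxygen on an aromatic ring. Among the compounds with values here, no measured step touches that oxygen, so the single available step does not bear on it, and nothing shows whether the change would move the number beyond the scatter in either direction. Compound 4 is therefore estimated at 40000 nM, within a range from 10000 nM to 160000 nM.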

Compound 4, half-maximal inhibitory concentration: 2240 nM
Beside the measured number, compound 4's estimate is 18-fold (1.25 log units) above it, and the stated range ends above it.
By their numbers in this assay, from the lowest: compound 4; then compounds 1 and 3 (each within the scatter of the next).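

Within the data shown here, compound 2 has no number, so no step from it to compound 4 can be read. The compounds shown leave open how far methoxy to (oxolan-3-yl)oxy moves a measured number. No evidence on hand bears on this result.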